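Aminothiophene series: dichlorophenyl piperazine variant at the adenosine receptor

The source may hold more compounds than are shown below. What is called first, only, known or untested is meant among the compounds shown, and "the series" means these compounds.

Three compounds in the series have been run in a functional assay on CHO cells with adenosine receptor A1 (Homo sapiens) as the target, read by cAMP accumulation and immunoassay, with a stated time of 6 min, tested at 10 uM; on this read-out lower numbers stand for a stronger effect and higher numbers for a weaker effect at the one concentration tested. Compound 1 `COc1ccc(N2CCN(Cc3csc(N)c3C(=O)c3ccc(Cl)cc3)CC2)cc1` gives -52%. Compound 2 `Nc1scc(CN2CCN(c3ccc(F)c(F)c3)CC2)c1C(=O)c1ccc(Cl)cc1` gives -87%, and compound 3 `Nc1scc(CN2CCN(c3cccc(F)c3F)CC2)c1C(=O)c1ccc(Cl)cc1` gives -79%. Compound 3 therefore sits at the lower end together with compound 2, the two values lying within the scatter (a number 8 percentage points higher from compound 2 to compound 3 (within the scatter)), and clearly apart from compound 1 (a number 27 percentage points lower from compound 1 to compound 3 (beyond the scatter)).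

Compound 4 `Nc1scc(CN2CCN(c3cc(Cl)ccc3Cl)CC2)c1C(=O)c1ccc(Cl)cc1` has not yet been run. It differs from compound 3 in one place: 2,5-dichlorophenyl in place of 2,3-difluorophenyl on an amine nitrogen in a ring.

Of the measured steps, the one bearing most directly is the swap of one difluorophenyl for another (a number 8 percentage points higher from compound 2 to compound 3 (within the scatter)), which stayed within the scatter. The two steps away from the methoxyphenyl (a number 35 percentage points lower from compound 1 to compound 2 (beyond the scatter) and a number 27 percentage points lower from compound 1 to compound 3 (beyond the scatter)) both moved to lower numbers, so the dihalogenated phenyl groups on the ring nitrogen so far share one level. A second dihalogenated phenyl is expected to hold near that level, so the expected step in this assay is a number 1 percentage points higher from compound 3 to compound 4 (within the scatter), not beyond the scatter, with some allowance for the change from fluorine to chlorine.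

For compound 4 the estimate in this assay is -78%, expected to lie between -96% and -55%.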

Compound 4, a percentage reported as activity, at one concentration (the size of the read-out at that concentration, not a potency): -62%
Compound 4: the middle estimate sits 16 percentage points below what was measured, within the range that was stated.
By their numbers in this assay, from the lowest: compounds 2 and 3 (each within the scatter of the next); then compounds 4 and 1 (each within the scatter of the next).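

In this assay two halogens on the phenyl group do not by themselves hold the level of the difluorophenyl compounds: the change gives a number 17 percentage points higher from compound 3 to compound 4 (beyond the scatter) and also a number 25 percentage points higher from compound 2 to compound 4 (beyond the scatter) in the comparison with the 3,4-difluorophenyl group. The 2,5-dichlorophenyl group instead stands level with the 4-methoxyphenyl group, with a number 10 percentage points lower from compound 1 to compound 4 (within the scatter) for that swap, so compound 4 goes against any single level for dihalogenated phenyl groups at this position. No supporting measurement is available to explain this separation.

Going by these compounds, the change alters the halogen and its placement together, so their separate contributions remain open; 2,5-difluorophenyl and 2,3-dichlorophenyl would divide them. Also open, on these data alone, is how a single chlorine on the phenyl group, as in 4-chlorophenyl, would compare.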